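The source may hold more compounds than are shown below. What is called first, only, known or untested is meant among the compounds shown, and "the series" means these compounds.

In a functional assay on MCF7 cells (Homo sapiens) for antiproliferative activity, read by MTT assay, with a stated time of 48 h (a lower number here means a stronger inhibitor, a higher number a weaker inhibitor), compound 2 `O=C(/C=C/c1ccc(Cl)cc1)Nc1cc(-c2ccccc2)[nH]n1` gives 970 nM. This lies within the usual scatter of compound 1 `Cc1ccc(-c2cc(NC(=O)/C=C/c3ccc(Cl)cc3)n[nH]2)cc1`, at 1190 nM, and also of compound 3 `O=C(/C=C\c1ccc(C(F)(F)F)cc1)Nc1cc(-c2ccccc2)[nH]n1`, at 540 nM. The unmeasured compound 4 `O=C(/C=C/c1ccc(Br)cc1)Nc1cc(-c2ccccc2)[nH]n1` differs from compound 2 by one small swap: bromo in place of chloro on an aromatic carbon. For the measured compounds named here, the only measured step that changes a single group on this scaffold is a 1.2-fold lower number from compound 1 to compound 2 (0.09 log units; within the scatter), which is small, although it involves a different group. Going by the values given here, no measured step shows this swap itself, so the expectation remains cautious. The step expected in this assay is none beyond the scatter, an estimated 1.0-fold lower number from compound 2 to compound 4 (0.01 log units; within the scatter). For compound 4 the expected value is 950 nM, with an estimated range from 500 nM to 1800 nM.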

Compound 4, half-maximal inhibitory concentration: 1240 nM
Compound 4: the middle estimate sits 1.3-fold (0.12 log units) below what was measured; the range from low to high includes it.
By their numbers in this assay, from the lowest: compounds 3, 2, 1 and 4 (each within the scatter of the next, the first and the last beyond it).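

In this assay, for the compounds shown here, this is the first direct look at the halogen on the aromatic carbon para to a large group: changing 4-chlorophenyl to 4-bromophenyl gives a 1.3-fold higher number from compound 2 to compound 4 (0.11 log units; within the scatter) and so stays within the scatter. At this position, the assay therefore cannot tell chloro and bromo apart. No measurement available here offers an explanation for this result. The compounds shown leave open whether an amine or a carboxylic acid at this place would give a number beyond the scatter.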